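The source may report more compounds than this note shows. Statements on the series, on what has been measured and on what is new or still open speak of the compounds shown alone.

Measured compounds:
- compound 1 `CC(C)c1ccc(NC(=O)N[C@H](C)c2ccccc2)cc1`: 49%
- compound 2 `CC(C)c1ccc(NC(=O)N[C@@H](C)c2ccccc2)cc1`: 86%
- compound 3 `C[C@H](NC(=O)Nc1ccccc1Cl)c1ccccc1`: 106%

The three compounds share one core, a urea bridging an aromatic ring and a chain carbon that carries a methyl group and a phenyl ring. In an ADME assay on the whole organism with Oryza sativa as the target, tested at 10 uM (on this read-out higher numbers stand for a weaker effect at the one concentration tested and lower numbers for a stronger effect), compound 1 gives 49%, the lowest number of the three. Compound 2 has the same atoms and bonds and differs only in how the chain carbon is drawn; the shift a number 37 percentage points higher from compound 1 to compound 2 (beyond the scatter) is large and rests on the fact that compounds 1 and 2 differ only in the configuration as drawn alone. Compound 3 carries a chloro group on the aromatic ring instead of isopropyl and in this assay gives 106%.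

Compound 4 `C[C@@H](NC(=O)Nc1ccc(I)cc1)c1ccccc1` is next. Relative to compound 1 the change is iodo in place of isopropyl on an aromatic carbon. Going by the values given here, no measured step covers an exchange of groups on the aromatic ring; the only step on record concerns configuration, and compound 3 differs from compound 1 in more than one place, so its value cannot be read as a step. The expectation for compound 4 is therefore loosely held: a step of a number 13 percentage points higher from compound 1 to compound 4 (beyond the scatter) is estimated, meaning compound 4 is expected to give about 62%, within a range from 30% to 94%.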

Compound 4, a percentage reported as activity, at one concentration (the size of the read-out at that concentration, not a potency): 85%
Beside the measured number, compound 4's estimate is 23 percentage points below it, within the range that was stated.
By their numbers in this assay, from the lowest: compound 1; then compounds 4 and 2 (each within the scatter of the next); then compound 3.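

Exchanging isopropyl for iodo on the aromatic carbon, with the chain carbon drawn the same way, gives in this assay a number 36 percentage points higher from compound 1 to compound 4 (beyond the scatter), and this large step means that the effect at the one concentration tested is stronger with isopropyl than with iodo in this pair. Going by these compounds alone, until now the only step on record came from configuration alone, a number 37 percentage points higher from compound 1 to compound 2 (beyond the scatter), so the group on the aromatic ring now stands as a second part of the structure where a single change moves the number by a large amount. Nothing on record bears on why this exchange has such an effect, and the one exchange shown gives no explanation by itself.

On these data alone, it remains open how an amine, a carboxylic acid or a longer chain would read in place of isopropyl, so one pair cannot yet show a trend for this position. It is also open whether the large step tied to configuration would return with iodo on the ring, since the compounds shown offer no pair that tests it.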